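Fluorine on the Ring: Compound 3 to Compound 4

The compounds below may be only part of what the source reports. "The series", "measured", "known", "first", "only" and "open" are said of these compounds alone.

The three measured compounds share one core bearing two benzyloxy groups. Compound 1, `O=C1O[C@H]([C@@H](O)Cn2ccc(NC(=O)c3ccccc3)nc2=O)C(OCc2ccccc2)=C1OCc1ccccc1`, gives 4790 nM in a functional assay on MCF7 cells (Homo sapiens) for inhibition, read by MTT assay, with a stated time of 72 h; on this read-out higher numbers stand for weaker inhibition and lower numbers for stronger inhibition. Compound 2, `O=C1O/C(=C\Cn2c(=O)[nH]c(=O)[nH]c2=O)C(OCc2ccccc2)=C1OCc1ccccc1`, gives 17800 nM in this assay. Compound 3, `NC1(CCn2ccc(=O)[nH]c2=O)OC(=O)C(OCc2ccccc2)=C1OCc1ccccc1`, reaches only a limit in this assay, namely > 100000 nM. Compound 3 therefore stands at the limit of > 100000 nM in this assay, at which 1 of the 3 values shown sits, and no number for it is known.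

Compound 4, `NC1(CCn2cc(F)c(=O)[nH]c2=O)OC(=O)C(OCc2ccccc2)=C1OCc1ccccc1`, differs from compound 3 in a single place: fluoro in place of hydrogen on an aromatic carbon. No step between two measured compounds covers this change, so its size cannot be read from the numbers shown. Because compound 3 sits at the limit of > 100000 nM in this assay, at which 1 of the 3 values shown sits, any movement could only appear as a number emerging from that limit; a modest gain, or none beyond the scatter, is expected. Compound 4 is estimated at 70000 nM in this assay, within a range from 20000 nM to 200000 nM. The expected step is an at least 1.4-fold lower number from compound 3 to compound 4 (0.15 log units; that floor lies within the scatter), with a substantial chance that only a limit is reported again.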

Compound 4, half-maximal inhibitory concentration: 20900 nM
For compound 4 the middle estimate is 3.3-fold (0.52 log units) above the measured one; the range from low to high includes it.
By their numbers in this assay, from the lowest: compound 1; then compounds 2 and 4 (each within the scatter of the next). At a limit, above all of these: compound 3.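

In this assay, among the compounds shown here, this single replacement gives an at least 4.7-fold lower number from compound 3 to compound 4 (0.67 log units; beyond the scatter), the first step between two measured compounds, and it shows that this aromatic carbon of the six-membered aromatic ring with 2 nitrogen is not indifferent to what it carries. The size of the step is only a floor, since compound 3 reaches nothing more than a limit: the limit of > 100000 nM in this assay, at which 1 of the 4 values shown sits. Compound 4 thus gives this side chain a measured number, which compound 3 could not provide.

As far as these compounds go, whether the gain is particular to fluoro, or would also appear with chloro or a methyl group on the same carbon, remains open. Also open, from the compounds shown here alone, is whether fluoro in place of hydrogen at this carbon would lower the number for compound 1 as well.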